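This account rests on a few compounds, and the source may have more. Where it says the series, first, only, none or still open, it means among the compounds named here.

Compound 2 `O=c1[nH]c2ccccc2n1CCCCN1CCN(C(c2ccccc2)c2ccccc2)CC1` gives, in an assay on RPMI-8226 cells for antagonist activity at P2X purinoceptor 7 (Homo sapiens), read by calcium flux (a higher number here means a weaker inhibitor, a lower number a stronger inhibitor), a value of 180 nM. Among the compounds with values here, of the two numbers in hand it is the lowest; the other belongs to compound 1 `O=c1[nH]c2ccccc2n1CCCN1CCC(C(O)(c2ccccc2)c2ccccc2)CC1`, which in this assay gives 7500 nM, a gap that lies beyond the scatter, though the two compounds differ in more than one place and no single step connects them. Compound 3 `Fc1cccc2c1ccn2CCCCN1CCN(C(c2ccccc2)c2ccccc2)CC1` has not been measured. It differs from compound 2 in one place: a group of 10 heavy atoms (8 carbon, 1 nitrogen, 1 fluorine; one five-membered aromatic ring with 1 hetero atom, one six-membered aromatic ring of carbon only) in place of a group of 10 heavy atoms (7 carbon, 2 nitrogen, 1 oxygen; one five-membered aromatic ring with 2 hetero atoms, one six-membered aromatic ring of carbon only), on a saturated chain carbon, four bonds along the chain from an amine nitrogen in a ring. Within the data shown here, no measured pair shows the effect of this exchange, so the expectation rests on the value of compound 2 alone. The group that leaves carries a hydrogen-bond donor that the entering group lacks, and the expected outcome is a modest weakening, a step of a 2.2-fold higher number from compound 2 to compound 3 (0.35 log units; beyond the scatter) that may still fall within the scatter. Compound 3 is estimated at 400 nM, within a range from 120 nM to 1500 nM.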

Compound 3, half-maximal inhibitory concentration: 150 nM
Compound 3: the middle estimate sits 2.7-fold (0.43 log units) above what was measured; the measured number falls inside the stated range.
By their numbers in this assay, from the lowest: compounds 3 and 2 (each within the scatter of the next); then compound 1.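

In this assay the exchange of the leaving group for 4-fluoro-1H-indol-1-yl gives a 1.2-fold lower number from compound 2 to compound 3 (0.08 log units; within the scatter) and so shows no change that can be told from the scatter. Within the data shown here, this is the first direct reading at this place, on a saturated chain carbon, four bonds along the chain from an amine nitrogen in a ring: with the rest of compound 2 held fixed, the hydrogen-bond donor and the double bond outside aromatic rings of the leaving group can both go without a step beyond the scatter. Nothing available accounts for this result.

The compounds shown leave open what the fluorine contributes, since an indol-1-yl group without it is not among them. They also leave open how far this tolerance extends to quite different groups at the same place, such as an amine or a carboxylic acid.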